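Furan for Cyanofluorophenyl on the Thiazole Core

This account rests on a few compounds, and the source may have more. Where it says the series, first, only, none or still open, it means among the compounds named here.

Measured so far:
compound 1, `O=C(O)Cc1sc(COc2ccc(Cl)cc2)nc1-c1ccc(Cl)cc1`, 370 nM
compound 2, `N#Cc1cc(-c2nc(C(c3ccc(F)cc3)c3ccc(F)cc3)sc2CC(=O)O)ccc1F`, 520 nM
compound 3, `CCC(c1ccccc1)c1nc(-c2ccc(Cl)cc2)c(CC(=O)O)s1`, > 100000 nM

In an in vitro functional assay on HEK285-7 cells for antagonist activity at prostaglandin D2 receptor 2 (Homo sapiens), read by BRET and beta-arrestin recruitment (a lower number here means a stronger inhibitor, a higher number a weaker inhibitor), compound 2 gives 520 nM. Compound 1 gives 370 nM, and the two numbers lie within the usual scatter of each other, so no order between them can be read. Compound 3 returns only a limit, > 100000 nM. That value is the limit of > 100000 nM in this assay, at which 1 of the 3 values shown sits.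

Compound 4, `O=C(O)Cc1sc(C(c2ccc(F)cc2)c2ccc(F)cc2)nc1-c1ccco1`, has not yet been measured. It differs from compound 2 by furan-2-yl in place of 3-cyano-4-fluorophenyl on an aromatic carbon. For the measured compounds named here, no measured pair shows this kind of change, and the replacement of a six-membered ring by a smaller five-membered one at this position gives no firm guide. A moderate loss of potency is expected, beyond the scatter, with the step of a 3.8-fold higher number from compound 2 to compound 4 (0.59 log units; beyond the scatter). Compound 4 is therefore estimated at 2000 nM, within a range from 500 nM to 10000 nM.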

Compound 4, half-maximal inhibitory concentration: 140 nM
The estimate for compound 4 lay 14-fold (1.15 log units) above the measured number, and the stated range ends above it.
By their numbers in this assay, from the lowest: compound 4; then compounds 1 and 2 (each within the scatter of the next). At a limit, above all of these: compound 3.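

In this assay furan-2-yl in place of 3-cyano-4-fluorophenyl, on the aromatic carbon next to the ring nitrogen, gives a 3.7-fold lower number from compound 2 to compound 4 (0.57 log units; beyond the scatter) on the shared core. This position therefore accepts a five-membered aromatic ring with 5 heavy atoms in place of a six-membered one with 9, with no loss of potency. Nothing measured here accounts for this step. Going by these compounds, it remains open whether the furan-2-yl ring itself matters, or only the absence of the nitrile and fluorine. An unsubstituted phenyl or a thiophen-2-yl group at this carbon would separate these, and neither stands among the compounds shown.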